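A few compounds are considered here, and "the series" means these few. Any claim that something is new, unique, unknown or untested is made for them only; others in the source may bear on it.

Compound 1, `C#CCNC1CCc2c(SCc3ccc(Br)cc3)cccc21`, gives 1310 nM in an assay on isolated protein for inhibition of Amine oxidase [flavin-containing] B (Homo sapiens); a lower number here means a stronger inhibitor, a higher number a weaker inhibitor. Compound 2, `C#CCNC1CCc2c(SCCc3cccc(C(F)(F)F)c3)cccc21`, gives 3720 nM in this assay. Compound 3, `C#CCNC1CCc2c(SCCc3cccc(Br)c3)cccc21`, gives 30500 nM in this assay.

Among these three measured compounds, compound 1 has the lowest number in this assay; compound 2 is the nearest to it and compound 3 the furthest, and both gaps lie beyond the usual scatter. Compound 3 and compound 2 share a core and differ in one place: trifluoromethyl in place of bromo on an aromatic carbon. This change gave an 8.2-fold lower number from compound 3 to compound 2 (0.91 log units; beyond the scatter). The difference between the core of compound 1 and the core of compound 3 is not broken down here.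

Compound 4, `C#CCNC1CCc2c(SCc3ccc(C(F)(F)F)cc3)cccc21`, has not yet been measured. It differs from compound 1 in one place: trifluoromethyl in place of bromo on an aromatic carbon. Within the data shown here, this is the same kind of change as the one from compound 3 to compound 2, but not the same, since in compound 3 the bromo stands meta to a large group, whereas in compound 1 it stands para to a large group. Among the measured compounds shown here, with only one earlier example of this change, on a different core and at a different place, a smaller step is expected than the earlier one. Resting on an 8.2-fold lower number from compound 3 to compound 2 (0.91 log units; beyond the scatter), the expected step is a 2.9-fold lower number from compound 1 to compound 4 (0.46 log units; beyond the scatter). Compound 4 is thus estimated at 450 nM, with a likely range from 120 nM to 1500 nM in this assay.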

Compound 4, half-maximal inhibitory concentration: 9680 nM
Beside the measured number, compound 4's estimate is 22-fold (1.33 log units) below it; the whole stated range lies below it.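

On the core of compound 1, trifluoromethyl in place of bromo on an aromatic carbon gave a 7.4-fold higher number from compound 1 to compound 4 (0.87 log units; beyond the scatter), so the gain seen with this change on the other core did not carry over. In this assay, the change therefore has no single direction across the two cores, and its outcome on one core gives no safe guide to its outcome on the other: the same change on two cores in this assay, an 8.2-fold lower number (0.91 log units; beyond the scatter) from compound 3 to compound 2 and a 7.4-fold higher number (0.87 log units; beyond the scatter) from compound 1 to compound 4, 61-fold (1.78 log units) apart, beyond the scatter of two such steps. The two examples differ both in the core and in where the group stands on the aromatic ring, so these two pairs cannot show which of those differences matters, or why the direction reverses.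

The compounds shown leave open whether the reversal follows the core or the place of the group, a question that bromo and trifluoromethyl at the other place on each core could settle. They also leave open how other groups at that place, such as chloro, methoxy or nitrile, would behave, and whether an oxygen in place of the sulfur would alter the outcome of the change.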